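The compounds below may be only part of what the source reports. "The series", "measured", "known", "first", "only" and "open" are said of these compounds alone.

Measured compounds in a functional assay on cells for positive allosteric modulation of metabotropic glutamate receptor 2 (Homo sapiens), read by fluorescence and calcium flux, with a stated time of 30 min; a higher number here means that more compound is needed for the effect, a lower number that less compound is needed:
compound 1 `Brc1cccc2c1nnn2CC1CCC1`: 20 nM
compound 2 `Brc1cccc2c1nnn2CC1CC1`: 70 nM
compound 3 `CCCCn1nnc2c(Br)cccc21`: 60 nM

Compound 3 stands among the higher numbers in this assay: one of the two steps that reach it (a 1.2-fold lower number from compound 2 to compound 3 (0.07 log units; within the scatter)) is within the scatter, whereas the other (a 3.0-fold higher number from compound 1 to compound 3 (0.48 log units; beyond the scatter)) is beyond it.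

Compound 4 `Cn1nnc2c(Br)cccc21` differs from compound 3 by hydrogen in place of propyl on a saturated chain carbon bound to an aromatic nitrogen. The measured steps that bear on this place are a 3.5-fold higher number from compound 1 to compound 2 (0.54 log units; beyond the scatter) and a 3.0-fold higher number from compound 1 to compound 3 (0.48 log units; beyond the scatter), both modest rises on going from cyclobutyl to a smaller group, while a 1.2-fold lower number from compound 2 to compound 3 (0.07 log units; within the scatter) is within the scatter. Going by the values given here, no measured step removes the chain altogether, so the expectation is uncertain; a further modest rise in this assay is expected, a 2.5-fold higher number from compound 3 to compound 4 (0.40 log units; beyond the scatter). Compound 4 is estimated at 150 nM (range 50 nM to 600 nM).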

Compound 4, half-maximal effective concentration: > 5000 nM
Compound 4 ended at the assay's limit; the forecaster's own chance of this, stated with the estimate: 15%; middle value at least 33-fold (1.52 log units) away from the limit.
By their numbers in this assay, from the lowest: compound 1; then compounds 3 and 2 (each within the scatter of the next). At a limit, above all of these: compound 4.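

In this assay, going by these compounds alone, cutting the butyl of compound 3 back to methyl, or replacing the cyclic groups of compound 2 and compound 1 with hydrogen at the same place, gives far larger steps than any seen among the earlier compounds: an at least 83-fold higher number from compound 3 to compound 4 (1.92 log units; beyond the scatter), an at least 71-fold higher number from compound 2 to compound 4 (1.85 log units; beyond the scatter) and an at least 250-fold higher number from compound 1 to compound 4 (2.39 log units; beyond the scatter). The group on a saturated chain carbon bound to an aromatic nitrogen is therefore needed for a measurable effect, and its exact form matters much less. Compound 4 stands at a limit, not a number: the limit of > 5000 nM in this assay, at which 1 of the 4 values shown sits.

Where between methyl and butyl the effect is lost remains open, and an ethyl chain would bear on this. Also open, as far as these compounds go, is whether a longer chain, or an amine or a carboxylic acid on the chain, would give a lower number than compound 1.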